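Iodo to Trifluoromethyl on Two Related Hydrazide Cores

A few compounds are considered here, and "the series" means these few. Any claim that something is new, unique, unknown or untested is made for them only; others in the source may bear on it.

Compound 1 `O=C(N/N=C/c1cc(I)cc(I)c1O)c1ccc(I)cc1` was tested in a functional assay on HepG2 cells (Homo sapiens) for cytotoxicity, with a stated time of 24 h (on this read-out lower numbers stand for stronger inhibition and higher numbers for weaker inhibition), where compound 1 gives 31800 nM. Compound 2 `O=C(N/N=C/c1cc(I)cc(I)c1O)c1ccc(C(F)(F)F)cc1` carries trifluoromethyl in place of iodo on an aromatic carbon. In this assay compound 2 gives 11700 nM. This change made a 2.7-fold lower number from compound 1 to compound 2 (0.43 log units; beyond the scatter). Compound 3 `O=C(NNC(=O)c1cc(I)cc(I)c1O)c1ccc(I)cc1` rests on a different core; how the core of compound 3 differs from the core of compound 1 is not broken down here. In this assay compound 3 gives 25100 nM. Going by the values given here, compound 4 `O=C(NNC(=O)c1cc(I)cc(I)c1O)c1ccc(C(F)(F)F)cc1` differs from compound 3 by trifluoromethyl in place of iodo on an aromatic carbon, the same change as the one made between compound 1 and compound 2, at the same place. Because that earlier change gave a 2.7-fold lower number from compound 1 to compound 2 (0.43 log units; beyond the scatter), a step of similar size is expected here, namely a 2.6-fold lower number from compound 3 to compound 4 (0.42 log units; beyond the scatter). On this basis compound 4 is estimated at 9500 nM, with a range from 4500 nM to 20000 nM.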

Compound 4, half-maximal inhibitory concentration: 167000 nM
Compound 4: the middle estimate sits 18-fold (1.24 log units) below what was measured, and the stated range ends below it.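

In this assay trifluoromethyl in place of iodo gave a 6.7-fold higher number from compound 3 to compound 4 (0.82 log units; beyond the scatter) and so ran in the opposite direction to the step on the core of compound 1. The change therefore cannot be carried from one core to the other in this series, since the two steps disagree: the same change on two cores in this assay, a 2.7-fold lower number (0.43 log units; beyond the scatter) from compound 1 to compound 2 and a 6.7-fold higher number (0.82 log units; beyond the scatter) from compound 3 to compound 4, 18-fold (1.26 log units) apart, beyond the scatter of two such steps. This rests on one pair per core, and it does not show which feature of the cores sets the two steps apart.

The compounds shown leave open whether another group at the same place, such as an amine or a carboxylic acid, would also move in opposite directions on the two cores. They also leave open how trifluoromethyl in place of iodo would behave on any third core.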